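Bromo for chloro at the assay limit

The source may hold more compounds than are shown below. What is called first, only, known or untested is meant among the compounds shown, and "the series" means these compounds.

Compound 1 `COc1ccc(Br)cc1C(C)NC(=O)NS(=O)(=O)c1ccc(C)cc1`: > 300000 nM (a limit)
Compound 2 `COc1ccc(Cl)cc1C(C)NC(=O)NS(=O)(=O)c1ccccc1`: > 300000 nM (a limit)

In a functional assay on thoracic aorta (Rattus norvegicus, strain Wistar), with a stated time of 15 min (on this read-out higher numbers stand for an effect only at larger amounts of compound and lower numbers for an effect already at smaller amounts), compound 2 stands at > 300000 nM, which is a limit of the assay and not a number. Compound 1 gives > 300000 nM, which is likewise a limit. The two measured compounds thus share a single reading: the limit of > 300000 nM in this assay, at which 2 of the 2 values shown sit. Among the compounds with values here, no measured step between compounds is available to size a change.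

Compound 3 `COc1ccc(Br)cc1C(C)NC(=O)NS(=O)(=O)c1ccccc1` differs from compound 2 in one place: bromo in place of chloro on an aromatic carbon. Bromo takes the place of chloro on an aromatic carbon, para to a methoxy group.

No step beyond the scatter is expected in this assay. This expectation rests on compound 2 with its limit of > 300000 nM. It also rests on compound 1, which carries bromo as well and has its limit of > 300000 nM. The estimated change is a number no higher from compound 2 to compound 3 (the limit leaves the size open). The expected value for compound 3 is 300000 nM. The estimated range for compound 3 runs from 100000 nM to 600000 nM, and a further limit is the likeliest report.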

Compound 3, half-maximal effective concentration: > 300000 nM
Compound 3: a limit, no number; the forecaster's own chance of this, stated with the estimate: 80%; the middle value lies on the limit itself.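

In this assay compound 3 gives > 300000 nM as a limit of the assay, not a number. Within the data shown here, no step from compound 1 or compound 2 to compound 3 can be read, and all three share one reading: the limit of > 300000 nM in this assay, at which 3 of the 3 values shown sit.

The compounds shown leave open what bromo in place of chloro, or hydrogen in place of methyl, does wherever this assay gives a number rather than a limit.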